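The source may hold more compounds than are shown below. What is called first, only, known or untested is meant among the compounds shown, and "the series" means these compounds.

Among the compounds with values here, in an ADME assay on HEK293 cells (Homo sapiens) for cytotoxicity, read by MTT assay, with a stated time of 72 h (on this read-out lower numbers stand for stronger inhibition and higher numbers for weaker inhibition), compound 1 `COc1ccc(C(=O)N2CCN(CC(=O)N3CCN(CCCc4c[nH]c5ccccc45)CC3)CC2)cc1` gives 156000 nM, and its only measured neighbour, compound 2 `O=C(CN1CCN(C(=O)c2cccc(Br)c2)CC1)N1CCN(CCCc2c[nH]c3ccccc23)CC1`, gives 80700 nM, so the two lie within the scatter of each other. Compound 3 `O=C(CN1CCN(C(=O)c2ccccc2F)CC1)N1CCN(CCCc2c[nH]c3ccccc23)CC1` differs from compound 1 at that same place: 2-fluorophenyl in place of 4-methoxyphenyl on a carbonyl carbon. Within the data shown here, the one measured step there, a 1.9-fold lower number from compound 1 to compound 2 (0.29 log units; within the scatter), stays within the scatter, so no step beyond the scatter is expected in this assay. The estimated step is a 1.4-fold lower number from compound 1 to compound 3 (0.15 log units; within the scatter). The expected value for compound 3 is 110000 nM, with an estimated range from 60000 nM to 200000 nM.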

Compound 3, half-maximal inhibitory concentration: 133000 nM
The estimate for compound 3 lay 1.2-fold (0.08 log units) below the measured number; low and high end bracket the measured number.
By their numbers in this assay, from the lowest: compounds 2, 3 and 1 (each within the scatter of the next).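

In this assay, 2-fluorophenyl on the carbonyl carbon gives a 1.2-fold lower number from compound 1 to compound 3 (0.07 log units; within the scatter) and a 1.6-fold higher number from compound 2 to compound 3 (0.22 log units; within the scatter), so a third aryl group at this place also stays within the scatter. The three compounds, carrying 4-methoxyphenyl, 3-bromophenyl and 2-fluorophenyl, cannot be told apart here. No evidence is available that bears on this result. From the compounds shown here alone, whether a phenyl ring carrying an amine or a carboxylic acid would step beyond the scatter at this place remains open. So does the effect of replacing the phenyl ring with a simple alkyl chain.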